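Sulfonamide series against malate dehydrogenase: compound 1 toward compound 4

A few compounds are considered here, and "the series" means these few. Any claim that something is new, unique, unknown or untested is made for them only; others in the source may bear on it.

Measured so far in an assay on isolated protein for inhibition of malate dehydrogenase, mitochondrial (Sus scrofa), with stated times of 45 min and 30 min; on this read-out lower numbers stand for stronger inhibition and higher numbers for weaker inhibition:
compound 1 `COc1cccc(S(=O)(=O)Nc2ccc3oc(-c4ccccc4)nc3c2)c1` gives > 63000 nM, a limit of the assay.
compound 2 `O=S(=O)(Nc1ccc(-c2nc3ccccc3o2)cc1)c1ccccc1F` gives > 63000 nM, a limit of the assay.
compound 3 `C=Cc1ccc(S(=O)(=O)Nc2ccc(-c3nc4ccccc4o3)cc2)cc1` gives > 63000 nM, a limit of the assay.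

Compound 1 stands only at a limit of this assay, with no number of its own. The same holds for compound 2 and compound 3, so that all three values sit at the limit of > 63000 nM in this assay, at which 3 of the 3 values shown sit. Within the data shown here, the one single-point step among the measured compounds, a step that the two limits leave unreadable from compound 2 to compound 3, is a step that the two limits leave unreadable, and it concerns the group on the sulfonyl sulfur, not the core.

Compound 4 `O=S(=O)(Nc1ccc2oc(-c3ccccc3)nc2c1)c1ccc(Cl)c(Cl)c1` differs from compound 1 in one place: 3,4-dichlorophenyl in place of 3-methoxyphenyl on a sulfonyl sulfur. Among the measured compounds shown here, no measured step bears on this change with a readable size; the only step involving a group on the sulfonyl sulfur is a step that the two limits leave unreadable from compound 2 to compound 3, unreadable. The expectation for compound 4 therefore rests on the fact that compound 1 sits at a limit and that every measured value is a limit. The step that the limit leaves unreadable from compound 1 to compound 4 is expected to lie within the scatter, with no readable direction. Compound 4 is estimated at 80000 nM in this assay, with a range from 15000 nM to 400000 nM, and most probably a limit again.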

Compound 4, half-maximal inhibitory concentration: > 63000 nM
Compound 4 was reported as a limit; the forecaster's own chance of this, stated with the estimate: 80%; the middle value is on the limit's open side.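

In this assay compound 4 gives > 63000 nM as a limit of the assay. No step can be read between compound 1 and compound 4, since both stand at the same limit: the limit of > 63000 nM in this assay, at which 4 of the 4 values shown sit.

As far as these compounds go, it remains open whether any group on the sulfonyl sulfur, or any change to the shared core, gives a readable value in this assay.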